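Changing the Amine-Linked Ring Pair on a Shared Core

This account rests on a few compounds, and the source may have more. Where it says the series, first, only, none or still open, it means among the compounds named here.

Compound 1 `Cn1c(=O)c(S(=O)(=O)c2ccc(F)cc2F)cc2cnc(Nc3ccc4occc4c3)nc21` gives 15000 nM in a functional assay on K562 cells (Homo sapiens) for inhibition, read by trypan blue exclusion, with a stated time of 72 h; a higher number here means a weaker inhibitor, a lower number a stronger inhibitor.
Compound 2 `Cn1c(=O)c(S(=O)(=O)c2ccc(F)cc2F)cc2cnc(Nc3ccc4[nH]c(C(=O)O)cc4c3)nc21` gives 10000 nM.
Compound 3 `Cn1c(=O)c(S(=O)(=O)c2ccc(F)cc2F)cc2cnc(Nc3ccc4cccc(O)c4n3)nc21` gives 5000 nM.

Compound 3 has the lowest number of the three: the step of a 3.0-fold lower number from compound 1 to compound 3 (0.48 log units; beyond the scatter) lies beyond the scatter, while the step of a 2.0-fold lower number from compound 2 to compound 3 (0.30 log units; within the scatter) does not, so compound 3 cannot be called the strongest outright. Compound 4 `Cn1c(=O)c(S(=O)(=O)c2ccc(F)cc2F)cc2cnc(Nc3ccc4c(c3)C(=O)C(=O)N4)nc21` differs from compound 3 by a group of 11 heavy atoms (8 carbon, 1 nitrogen, 2 oxygen; one five-membered non-aromatic ring with 1 hetero atom, one six-membered aromatic ring of carbon only) in place of a group of 11 heavy atoms (9 carbon, 1 nitrogen, 1 oxygen; one six-membered aromatic ring of carbon only, one six-membered aromatic ring with 1 hetero atom), on a nitrogen on an aromatic ring. All three measured steps vary this same group, and they were small: a 1.5-fold lower number from compound 1 to compound 2 (0.18 log units; within the scatter) and a 2.0-fold lower number from compound 2 to compound 3 (0.30 log units; within the scatter) stayed within the scatter, only a 3.0-fold lower number from compound 1 to compound 3 (0.48 log units; beyond the scatter) went slightly beyond it. A change of similar size, or none beyond the scatter, is therefore expected here. Compound 4 is estimated at 8000 nM, between 3000 nM and 20000 nM, an expected step of a 1.6-fold higher number from compound 3 to compound 4 (0.20 log units; within the scatter).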

Compound 4, half-maximal inhibitory concentration: 30000 nM
Compound 4: the middle estimate sits 3.8-fold (0.57 log units) below what was measured, and the stated range ends below it.
By their numbers in this assay, from the lowest: compounds 3, 2, 1 and 4 (each within the scatter of the next, the first and the last beyond it).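

Swapping 8-hydroxyquinolin-2-yl for the new group keeps the heavy-atom, donor and acceptor counts the same, yet this assay shows a 6.0-fold higher number from compound 3 to compound 4 (0.78 log units; beyond the scatter), so this position can shift the number even when those counts do not change. Compound 4 also separates from compound 2, with a 3.0-fold higher number from compound 2 to compound 4 (0.48 log units; beyond the scatter), but not from compound 1, with a 2.0-fold higher number from compound 1 to compound 4 (0.30 log units; within the scatter). Nothing measured here explains these steps.

Still open, from the compounds shown here alone, is what a plain quinolin-2-yl, lacking the hydroxy group, would give. A phenyl ring carrying an amine at this nitrogen also remains untested among the compounds shown.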